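A Ketone in Place of an Ester on a Shared Core

The compounds below may be only part of what the source reports. "The series", "measured", "known", "first", "only" and "open" are said of these compounds alone.

Measured compounds:
- compound 1, `CCCOC(=O)C1=C(C)NC(=O)NC1c1ccoc1`: 50%
- compound 2, `CCCOC(=O)C1=C(C)NC(=O)NC1c1ccsc1`: 44%
- compound 3, `CCCOC(=O)C1=C(C)N(C)C(=O)NC1c1ccsc1`: 2%

All three were tested in an assay on membranes from CHO cells for displacement of a labelled ligand from adenosine receptor A1 (Homo sapiens), read by scintillation counting, with a stated time of 60 min, tested at 1 uM; on this read-out higher numbers stand for more inhibition at the one concentration tested (going by the name of the read-out) and lower numbers for less inhibition. Compound 2 stands second highest of the three numbers; its nearest neighbour is compound 1, and the two differ only by a number 6 percentage points lower from compound 1 to compound 2 (within the scatter). Its furthest neighbour is compound 3, reached by a number 42 percentage points lower from compound 2 to compound 3 (beyond the scatter).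

The next compound, compound 4, `CC1=C(C(=O)CC(C)C)C(c2ccsc2)NC(=O)N1`, has not been measured. It differs from compound 2 at one place: isobutyl in place of propoxy on a carbonyl carbon. Put differently, the propoxycarbonyl of compound 2 becomes an isobutylcarbonyl, so an ester is turned into a ketone while the rest of the molecule is kept.

Neither measured step bears directly on this change. The step from compound 1 to compound 2 swaps a ring on a saturated ring carbon and stays within the scatter; the step from compound 2 to compound 3 adds a methyl to an amide-type nitrogen in a ring and is large. Nothing measured touches the carbonyl substituent, so the expectation for compound 4 must lean on the value of compound 2 alone, with a wide margin.

For compound 4 the expected result in this assay is therefore 35%, in the range 5% to 60%, which is an expected step of a number 9 percentage points lower from compound 2 to compound 4 (within the scatter).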

Compound 4, a percentage reported as inhibition, at one concentration (the size of the read-out at that concentration, not a potency): 37%
The estimate for compound 4 lay 2 percentage points below the measured number, within the range that was stated.
By their numbers in this assay, from the lowest: compound 3; then compounds 4, 2 and 1 (each within the scatter of the next, the first and the last beyond it).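

Swapping propoxy for isobutyl on the carbonyl carbon turns the ester of compound 2 into a ketone and gives, in this assay, a number 7 percentage points lower from compound 2 to compound 4 (within the scatter), the first measured change at this carbonyl substituent. Within this pair, then, the ester is not required for this level of inhibition at the one concentration tested, even though the group that leaves counts 1 hydrogen-bond acceptor and the group that enters counts 0, with 4 heavy atoms on each side. No measurement at hand explains why this exchange leaves the number within the scatter.

The compounds shown leave open whether the carbonyl carbon would accept other groups in the same way, such as a longer chain, an amine that would make an amide, or a hydroxyl that would make a carboxylic acid. They also leave open whether the ketone would behave the same way with furan-3-yl on the saturated ring carbon or with methyl on the amide-type nitrogen, and whether a full potency measurement would separate compound 2 from compound 4.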